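Cytotoxicity notes on a naphthyl sulfonamide replacement

This account rests on a few compounds, and the source may have more. Where it says the series, first, only, none or still open, it means among the compounds named here.

Measured so far:
compound 1 `O=S(=O)(Nc1ncc(C(Oc2ccc3cc(Br)ccc3c2)c2ccc(Cl)cc2)s1)c1ccc(Cl)cc1` — "not toxic" (no number reported)
compound 2 `O=S(=O)(Nc1ncc(C(Oc2ccc3cc(Br)ccc3c2)c2ccc(Cl)cc2)s1)c1ccc2c(c1)CCO2` — > 50000 nM

In an ADME assay on HepG2 2.2.15 cells (Homo sapiens) for cytotoxicity (on this read-out higher numbers stand for lower toxicity in this test and lower numbers for higher toxicity in this test), compound 1 is reported only as "not toxic" (no number reported), without a number. Compound 2 gives > 50000 nM in this assay, and that value is a limit of the assay, not a number. Among the compounds with values here, compound 2 therefore stands at the limit of > 50000 nM in this assay, at which 1 of the 2 values shown sits; neither compound carries a single number, so no measured step between them exists and no step size can be read from these data.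

Compound 3 `O=S(=O)(Nc1ncc(C(Oc2ccc3cc(Br)ccc3c2)c2ccc(Cl)cc2)s1)c1ccc2ccccc2c1` is not yet measured. It differs from compound 2 by a group of 10 heavy atoms (10 carbon; 2 six-membered aromatic rings of carbon only) in place of a group of 9 heavy atoms (8 carbon, 1 oxygen; one five-membered non-aromatic ring with 1 hetero atom, one six-membered aromatic ring of carbon only), on a sulfonyl sulfur. Within the data shown here, with no measured step available, the expected change in this assay is none beyond the scatter. The step that the limit leaves unreadable from compound 2 to compound 3 is expected to be small. For compound 3 the estimate in this assay is 60000 nM, with a range from 20000 nM to 150000 nM, and a further limit-only result is considered likely.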

Compound 3, half-maximal cytotoxic concentration: > 50000 nM
Compound 3: no number, only a limit; the forecaster's own chance of this, stated with the estimate: 70%; the middle value is on the limit's open side.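

No step from compound 2 to compound 3 can be read in this assay because both results are limits, not numbers: the limit of > 50000 nM in this assay, at which 2 of the 3 values shown sit.

The compounds shown leave open where their actual half-maximal cytotoxic concentrations lie, and so whether naphthalen-2-yl on the sulfonyl sulfur makes any difference.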